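The source may hold more compounds than are shown below. What is called first, only, known or untested is meant among the compounds shown, and "the series" means these compounds.

Going by the values given here, in an assay on CHO cells for binding affinity to metabotropic glutamate receptor 2 (Rattus norvegicus) (on this read-out higher numbers stand for weaker inhibition and lower numbers for stronger inhibition), compound 1 `N[C@]1(C(=O)O)[C@H]2[C@@H](C[C@H]1OCCCc1ccccc1)[C@]2(F)C(=O)O` gives 9.83 nM, the highest of the three numbers measured so far, though the gaps to compound 2 `N[C@]1(C(=O)O)[C@H]2[C@@H](C[C@H]1OCc1ccccc1Cl)[C@]2(F)C(=O)O` at 4.99 nM and to compound 3 `N[C@]1(C(=O)O)[C@H]2[C@@H](C[C@H]1OCc1cccc([N+](=O)[O-])c1)[C@]2(F)C(=O)O` at 7.87 nM both lie within the scatter. Compound 4 `Nc1cccc(CO[C@@H]2C[C@@H]3[C@H]([C@]2(N)C(=O)O)[C@@]3(F)C(=O)O)c1` has not yet been measured; it differs from compound 1 in a single place: 3-aminophenyl in place of phenethyl on a saturated chain carbon bound to an oxygen on a saturated carbon. Among the compounds with values here, one measured step bears on this place, a 2.0-fold lower number from compound 1 to compound 2 (0.29 log units; within the scatter), which stayed within the scatter, and the value of compound 3 also sits close to compound 1. Within the data shown here, each change at this place so far has left the number roughly where it was, so for compound 4 a step of about a 1.2-fold lower number from compound 1 to compound 4 (0.09 log units; within the scatter) is expected, that is, none beyond the scatter. Compound 4 is therefore estimated at 8 nM, with a range from 3 nM to 25 nM.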

Compound 4, inhibition constant: 15.4 nM
Compound 4: the middle estimate sits 1.9-fold (0.28 log units) below what was measured; low and high end bracket the measured number.
By their numbers in this assay, from the lowest: compounds 2, 3, 1 and 4 (each within the scatter of the next, the first and the last beyond it).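

In this assay this position now shows a step beyond the scatter, a modest one, with a 3.1-fold higher number from compound 2 to compound 4 (0.49 log units; beyond the scatter) for 3-aminophenyl in place of 2-chlorophenyl. The steps of a 1.6-fold higher number from compound 1 to compound 4 (0.19 log units; within the scatter) and a 2.0-fold higher number from compound 3 to compound 4 (0.29 log units; within the scatter) both stay within the scatter, so amino in place of nitro on an aromatic carbon cannot be told from no change. Nothing measured here accounts for the gap between these groups. Still open, on these data alone, is whether a carboxylic acid or a methoxy group on the aromatic ring would carry the number beyond the scatter from compound 1.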